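A few compounds are considered here, and "the series" means these few. Any claim that something is new, unique, unknown or untested is made for them only; others in the source may bear on it.

Measured so far:
compound 1, `CCOc1ccccc1/C=C/c1ccc2c(Cl)cc(Cl)c(O)c2n1`: 5.67
compound 2, `CCOc1ccccc1/C=C/c1ccc2cccc(O)c2n1`: 4.55
compound 3, `CCOc1ccc(/C=C/c2ccc3ccccc3n2)cc1`: 4.61

In a physicochemical assay for lipophilicity, read by HPLC (a higher number here means a more lipophilic compound, a lower number a more polar compound), compound 1 gives the highest of the three numbers. The nearest of the other two is compound 3, whose value of 4.61 lies beyond the usual scatter below it. Compound 2 stands furthest away, and its value of 4.55 is likewise beyond the scatter below that of compound 1. For the measured compounds named here, no pair of these three compounds differs in only one place, so no single step between measured compounds can be read off.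

Compound 4, `Oc1c(Cl)cc(Cl)c2ccc(/C=C/c3ccccc3Cl)nc12`, has not yet been measured in this assay. Compared with compound 1 it shows one change: chloro in place of ethoxy on an aromatic carbon. The change sits ortho to a large group, and the rest of the shared core is untouched. Going by the values given here, with nothing among the measured compounds to set its size, the expectation for this assay is a small rise, at most on the edge of the scatter. Compound 4 is thus estimated at 5.9, with a range from 5.5 to 6.3. That estimate corresponds to an expected step of a number 0.23 log units higher from compound 1 to compound 4 (within the scatter).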

Compound 4, partition coefficient: 6.02
The estimate for compound 4 lay 0.12 log units below the measured number; the measured number falls inside the stated range.
By their numbers in this assay, from the lowest: compounds 2 and 3 (each within the scatter of the next); then compound 1; then compound 4.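

In this assay, for the compounds shown here, the change of chloro in place of ethoxy on an aromatic carbon, ortho to a large group, gives the first step that can be read at a single place: a number 0.35 log units higher from compound 1 to compound 4 (beyond the scatter). At this position, the change swaps three heavy atoms, one of them a hydrogen-bond acceptor, for one chlorine, and the number still goes up by a modest amount. Nothing at hand shows what lies behind this step.

The compounds shown leave open how other groups at this place would read, such as a methoxy, an amine or a carboxylic acid. They also leave open whether chloro in place of ethoxy would give a similar step on the core of compound 2.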